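Removing the Octylcarbonyl from Compound 1

The source may report more compounds than this note shows. Statements on the series, on what has been measured and on what is new or still open speak of the compounds shown alone.

Compound 1 `CCCCCCCCC(=O)N1c2ccccc2CCC1C(=O)Nc1ccccc1C(F)(F)F` is tested in a functional assay on ACHN cells (Homo sapiens) for cytotoxicity, read by sulforhodamine B assay, with a stated time of 72 h (on this read-out higher numbers stand for weaker inhibition of growth and lower numbers for stronger inhibition of growth), where compound 1 gives 8330 nM. This is the higher of the two numbers recorded; compound 3 `O=C(Nc1ccccc1O)C1CCc2ccccc2N1C(=O)c1ccccc1` gives 4260 nM, and the two values lie within the scatter of each other. For compound 2 `CC(=O)N1c2ccccc2CCC1C(=O)Nc1cc(C(F)(F)F)cc(C(F)(F)F)c1` the assay reports only a limit, > 70000 nM, as noted in the limit of > 70000 nM in this assay, at which 1 of the 3 values shown sits. Compound 4 `O=C(Nc1ccccc1C(F)(F)F)C1CCc2ccccc2N1` has not been measured. It differs from compound 1 in one place: hydrogen in place of octylcarbonyl on a nitrogen on an aromatic ring in a ring. Among the compounds with values here, no measured pair shows what this change does, and the three measured compounds differ in several places at once. The step expected in this assay is a 2.4-fold higher number from compound 1 to compound 4 (0.38 log units; beyond the scatter), toward weaker inhibition, possibly not beyond the scatter. Compound 4 is thus estimated at 20000 nM, between 5000 nM and 70000 nM.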

Compound 4, concentration for 50% growth inhibition: 57600 nM
Estimate against measurement, compound 4: 2.9-fold (0.46 log units) below, within the range that was stated.
By their numbers in this assay, from the lowest: compounds 3 and 1 (each within the scatter of the next); then compound 4. At a limit, above all of these: compound 2.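

In this assay, within the data shown here, hydrogen in place of octylcarbonyl on this nitrogen gives a 6.9-fold higher number from compound 1 to compound 4 (0.84 log units; beyond the scatter), the first step that can be read at this position. In this pair, growth inhibition therefore weakens once the octylcarbonyl is gone, although compound 4 still gives a measured number. Compound 2 alone stands at a limit and not at a number: the limit of > 70000 nM in this assay, at which 1 of the 4 values shown sits.

From the compounds shown here alone, whether a longer chain on this nitrogen would keep or change the inhibition seen with compound 1 remains open. The same holds for a chain ending in a carboxylic acid or an amine.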